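The source may hold more compounds than are shown below. What is called first, only, known or untested is meant among the compounds shown, and "the series" means these compounds.

Measured so far in a functional assay on MCF7 cells (Homo sapiens) for cytotoxicity, read by MTT assay, with a stated time of 48 h; on this read-out higher numbers stand for weaker inhibition and lower numbers for stronger inhibition:

Compound 1 `[O-][S+](CCC(F)=C(F)F)c1ncc(-c2ccncc2)s1` gives only a limit of this assay, > 120000 nM.
Compound 2 `FC(F)=C(F)CCSc1nccs1` gives only a limit, > 120000 nM.
Compound 3 `FC(F)=C(F)CCSc1ncc(-c2ccncc2)s1` gives only a limit, > 120000 nM.

Compound 4 `[O-][S+](CCC(F)=C(F)F)c1nccs1` is not yet measured. It differs from compound 1 by hydrogen in place of pyridin-4-yl on an aromatic carbon. The same kind of change has been made once before, from compound 3 to compound 2, (hydrogen in place of pyridin-4-yl on an aromatic carbon); the two places differ only in that the ring atom two ring bonds away bears a group of 9 heavy atoms in compound 1 and a group of 8 heavy atoms in compound 3. That earlier step, a step that the two limits leave unreadable from compound 3 to compound 2, cannot be sized, because of the limit of > 120000 nM in this assay, at which 3 of the 3 values shown sit. The difference between the core of compound 1 and the core of compound 3 is not broken down here. With every value sitting at the limit, the step from compound 1 to compound 4 is expected to be a number no higher from compound 1 to compound 4 (the limit leaves the size open). Compound 4 is therefore estimated at 120000 nM, most likely again reported only as a limit, with a range from 60000 nM to 240000 nM.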

Compound 4, half-maximal inhibitory concentration: > 120000 nM
Compound 4 was reported as a limit; the forecaster's own chance of this, stated with the estimate: 85%; the middle value lies on the limit itself.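

No step can be read from compound 1 to compound 4 in this assay, because neither result is a number, only a limit: the limit of > 120000 nM in this assay, at which 4 of the 4 values shown sit. The compounds shown leave open how strongly any of them acts and whether replacing pyridin-4-yl with hydrogen changes that.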